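Replacing the lactam arm of compound 3 with methylsulfanyl

The source may hold more compounds than are shown below. What is called first, only, known or untested is meant among the compounds shown, and "the series" means these compounds.

Compound 3 `O=C1CCCN1Cc1ncnc2c1ncn2[C@@H]1O[C@H](CO)[C@@H](O)[C@H]1O` is the only one of the three measured compounds to yield an actual number in a functional assay on Huh-7 cells (Homo sapiens) for cytotoxicity, read by MTT assay, with a stated time of 3 days (a higher number here means that more compound is tolerated, a lower number that less compound is tolerated), giving 45000 nM. Compound 1 `OC[C@H]1O[C@@H](n2cnc3c(CSc4ccccc4)ncnc32)[C@H](O)[C@@H]1O` reaches only a limit of the assay, > 100000 nM. Compound 2 `OC[C@H]1O[C@@H](n2cnc3c(CSCc4ccccc4)ncnc32)[C@H](O)[C@@H]1O` likewise stops at a limit, > 100000 nM. Two of the three values shown are thus (the limit of > 100000 nM in this assay, at which 2 of the 3 values shown sit). Compound 4 `CSCc1ncnc2c1ncn2[C@@H]1O[C@H](CO)[C@@H](O)[C@H]1O` differs from compound 3 by methylsulfanyl in place of 2-oxopyrrolidin-1-yl on a saturated chain carbon bound to an aromatic carbon. Among the measured compounds shown here, the steps that bear on this change are an at least 2.2-fold lower number from compound 1 to compound 3 (0.34 log units; beyond the scatter) and an at least 2.2-fold lower number from compound 2 to compound 3 (0.34 log units; beyond the scatter), both showing the 2-oxopyrrolidin-1-yl group with a lower number than phenylsulfanyl or benzylsulfanyl. Returning to a sulfanyl group is therefore expected to move the number back up, quite possibly to a limit again. Compound 4 is estimated at 100000 nM, with a range from 40000 nM to 300000 nM. This estimate is expected to correspond to a 2.2-fold higher number from compound 3 to compound 4 (0.35 log units; beyond the scatter).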

Compound 4, half-maximal cytotoxic concentration: > 100000 nM
Compound 4: no number, only a limit; the forecaster's own chance of this, stated with the estimate: 60%; the middle value lies on the limit itself.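

In this assay, the change gives an at least 2.2-fold higher number from compound 3 to compound 4 (0.34 log units; beyond the scatter), so the 2-oxopyrrolidin-1-yl group now stands lower against methylsulfanyl, which has no ring, as well as against phenylsulfanyl and benzylsulfanyl. Compound 4 gives > 100000 nM, which is a limit and not a number. The steps from compound 1 and compound 2 to compound 4 join two limits and cannot be read, and the limit now holds most of the series: the limit of > 100000 nM in this assay, at which 3 of the 4 values shown sit.

The three sulfanyl compounds cannot be ranked against one another. On these data alone, whether an amine or a carboxylic acid on the same saturated chain carbon would lower the number as 2-oxopyrrolidin-1-yl does remains open.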